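Ortho-Methyl on the Sulfonyl Phenyl of Compound 3

This account rests on a few compounds, and the source may have more. Where it says the series, first, only, none or still open, it means among the compounds named here.

Measured so far in an assay on isolated protein for binding affinity to histamine H2 receptor (Homo sapiens); a lower number here means a stronger inhibitor, a higher number a weaker inhibitor:
compound 1 `O=C(c1ccc(OCCCN2CC[C@H](NS(=O)(=O)c3cccc(F)c3)C2)cc1)C1CC1` gives 1600 nM;
compound 2 `N#Cc1ccc(S(=O)(=O)N[C@H]2CCN(CCCOc3ccc(C(=O)C4CC4)cc3)C2)cc1` gives 1600 nM;
compound 3 `O=C(c1ccc(OCCCN2CC[C@H](NS(=O)(=O)c3ccccc3)C2)cc1)C1CC1` gives 1200 nM.

Compound 3 stands lowest of the three numbers, but only narrowly: the step of a 1.3-fold lower number from compound 1 to compound 3 (0.12 log units; within the scatter) and the step of a 1.3-fold lower number from compound 2 to compound 3 (0.12 log units; within the scatter) are both within the scatter, so the three compounds cannot be told apart on these numbers. The step of no change at the digits printed from compound 1 to compound 2 (within the scatter) likewise shows no change.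

Compound 4 `Cc1ccccc1S(=O)(=O)N[C@H]1CCN(CCCOc2ccc(C(=O)C3CC3)cc2)C1` differs from compound 3 by methyl in place of hydrogen on an aromatic carbon. The measured steps that bear on this are those on the same six-membered ring of carbon only that carries the sulfonyl sulfur: the step from compound 1 to compound 3 removed a fluoro, and the step from compound 2 to compound 3 removed a cyano, and neither moved the number beyond the scatter. Nothing measured here probes a methyl at the place ortho to a large group, so the expectation rests on those two flat steps alone. In this assay the step of a 1.1-fold higher number from compound 3 to compound 4 (0.03 log units; within the scatter) is therefore expected to stay within the scatter, with no direction. Compound 4 is estimated at 1300 nM, with a range of 450 nM to 3800 nM.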

Compound 4, inhibition constant: 2200 nM
Estimate against measurement, compound 4: 1.7-fold (0.23 log units) below; the range from low to high includes it.
By their numbers in this assay, from the lowest: compounds 3, 1, 2 and 4 (each within the scatter of the next).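

In this assay, the methyl is the first group shown on an aromatic carbon ortho to a large group, and the step (a 1.8-fold higher number from compound 3 to compound 4 (0.26 log units; within the scatter)) shows that this place on the ring tolerates a methyl without a change that can be told from the scatter. Set against the other two substituted rings, 2-methylphenyl on the sulfonyl sulfur also cannot be told apart from 3-fluorophenyl (a 1.4-fold higher number from compound 1 to compound 4 (0.14 log units; within the scatter)) or from 4-cyanophenyl (a 1.4-fold higher number from compound 2 to compound 4 (0.14 log units; within the scatter)), so all four aryl groups shown on that sulfur read alike within this set. Nothing available explains these numbers or says what this place on the ring does.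

The compounds shown leave open whether an amine or a carboxylic acid at this same place would move the number beyond the scatter, and whether a methyl elsewhere on the ring would read the same. They also leave open how far the number depends on the rest of the molecule, such as a longer chain in place of the one joining the shared core to the aromatic ether.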